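Benzamido at the Arylring of a Cytotoxic Cyclopentenone

The source may hold more compounds than are shown below. What is called first, only, known or untested is meant among the compounds shown, and "the series" means these compounds.

Compounds measured:
compound 1, `C=CCOc1cc(C2=C(c3cc(OC)c(OC)c(OC)c3)C(=O)C(O)C2)ccc1OC`, > 100 ug/mL
compound 2, `COc1ccc(C2=C(c3cc(OC)c(OC)c(OC)c3)C(=O)C(O)C2)cc1`, < 1 ug/mL

Compound 1 and compound 2 share a core and were both tested in an ADME assay on HT-29 cells (Homo sapiens) for cytotoxicity, read by MTT assay, with a stated time of 72 h; a higher number here means a weaker inhibitor, a lower number a stronger inhibitor. For compound 1 the value > 100 ug/mL is a limit of the assay, not a number (the limit of > 100 ug/mL in this assay, at which 1 of the 2 values shown sits). For compound 2 the value < 1 ug/mL is likewise a limit (the limit of < 1 ug/mL in this assay, at which 1 of the 2 values shown sits). For the measured compounds named here, the one step between them, an at least 100-fold lower number from compound 1 to compound 2 (2.00 log units; beyond the scatter), shows that a substituent in place of hydrogen on an aromatic carbon separates the two limits widely.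

Compound 3, `COc1ccc(C2=C(c3cc(OC)c(OC)c(OC)c3)C(=O)C(O)C2)cc1NC(=O)c1ccccc1`, has not yet been measured. It differs from compound 2 by benzamido in place of hydrogen on an aromatic carbon. Going by the values given here, the only measured step that bears on this change is an at least 100-fold lower number from compound 1 to compound 2 (2.00 log units; beyond the scatter), which concerns the same kind of exchange, hydrogen against a substituent on an aromatic carbon of that ring, run in the opposite direction. By that analogy a large step upward is expected for compound 3, an at least 30-fold higher number from compound 2 to compound 3 (1.47 log units; beyond the scatter), with the chance that the assay again reports only a limit. The estimate for compound 3 is 30 ug/mL, within 3 ug/mL to 100 ug/mL.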

Compound 3, half-maximal inhibitory concentration: > 100 ug/mL
Compound 3: no number, only a limit; the forecaster's own chance of this, stated with the estimate: 40%; at least 3.3-fold (0.52 log units) between middle value and limit.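

In this assay, putting benzamido on the aromatic carbon ortho to a methoxy group gives an at least 100-fold higher number from compound 2 to compound 3 (2.00 log units; beyond the scatter), so this carbon tolerated neither of the two substituents shown, and the loss is not particular to allyloxy. Allyloxy in compound 1 and benzamido in compound 3, two groups with little in common but their attachment to this carbon, now end at the same upper limit, while compound 2, with hydrogen there, remains at the lower limit: the limit of > 100 ug/mL in this assay, at which 2 of the 3 values shown sit. Both compound 1 and compound 3 give only a limit, so the step between them cannot be read and the two groups cannot be ranked against each other.

The compounds shown leave open whether a small group on this carbon, such as an amine, a hydroxyl or a fluorine, would keep the activity of compound 2 or lose it as allyloxy and benzamido do. They also leave open how far the true value of compound 2 lies from its limit, and thus the full size of the step, and whether benzamido on another carbon of this ring would have the same outcome.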